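Working notes: from compound 3 to compound 4

This account rests on a few compounds, and the source may have more. Where it says the series, first, only, none or still open, it means among the compounds named here.

Measured in an ADME assay on HEK293 cells (Homo sapiens) for cytotoxicity, read by sulforhodamine B assay, with a stated time of 48 h, tested at 10 uM; a lower number here means less inhibition, a higher number more inhibition at the concentration tested (going by the name of the read-out):
- compound 1 `COc1nc2ccc(Br)cc2cc1C(c1ccccc1)n1cc(C2CC2)nn1` gives 8.22%
- compound 2 `COc1nc2ccc(Br)cc2cc1C(c1ccccc1)n1cc(-c2ccccc2F)nn1` gives 3.97%
- compound 3 `CCCCCCCc1cn(C(c2ccccc2)c2cc3cc(Br)ccc3nc2OC)nn1` gives 0.17%

Compound 3 sits at the low end of these three numbers, but the gaps to the others are small: a number 3.8 percentage points lower from compound 2 to compound 3 (within the scatter) and a number 8.1 percentage points lower from compound 1 to compound 3 (within the scatter) both fall within the scatter, so the three compounds are not separated by this assay.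

Compound 4 `COc1nc2ccc(Br)cc2cc1C(c1ccccc1)n1cc(-c2cccc(F)c2)nn1` is the next member. It differs from compound 3 in one place: 3-fluorophenyl in place of heptyl on an aromatic carbon.

For the measured compounds named here, the closest precedent is the reverse of a number 3.8 percentage points lower from compound 2 to compound 3 (within the scatter), where a fluorophenyl group stood at the same position, together with a number 4.3 percentage points lower from compound 1 to compound 2 (within the scatter); neither moved beyond the scatter. On that basis no step beyond the scatter is expected for compound 4 either, with a number 3.8 percentage points higher from compound 3 to compound 4 (within the scatter) as the expected change. Compound 4 is therefore estimated to give 4% in this assay, in the range -4% to 12%.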

Compound 4, a percentage reported as inhibition, at one concentration (the size of the read-out at that concentration, not a potency): 6.84%
For compound 4 the middle estimate is 2.8 percentage points below the measured one; low and high end bracket the measured number.
By their numbers in this assay, from the lowest: compounds 3, 2, 4 and 1 (each within the scatter of the next).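

In this assay the series now holds a change in where the fluorine sits on the phenyl group: 3-fluorophenyl in place of 2-fluorophenyl gives a number 2.9 percentage points higher from compound 2 to compound 4 (within the scatter) and so does not separate the two compounds. The same group gives a number 6.7 percentage points higher from compound 3 to compound 4 (within the scatter) in place of heptyl and a number 1.4 percentage points lower from compound 1 to compound 4 (within the scatter) in place of cyclopropyl, so all four groups shown on this aromatic carbon of the five-membered ring remain within the scatter of one another. Nothing at hand bears on the reason for these numbers.

Still open, from the compounds shown here alone, is whether an amine, a carboxylic acid or a chain longer than heptyl on this carbon would give a step beyond the scatter. Changes elsewhere on the shared core also remain open.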